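From pyridin-2-yl to pyridin-4-yl on the amide side chain

A few compounds are considered here, and "the series" means these few. Any claim that something is new, unique, unknown or untested is made for them only; others in the source may bear on it.

Measured in a functional assay on KB cells (Homo sapiens) for antiproliferative activity, read by MTT assay, with a stated time of 72 h, in the presence of a further agent that is not named here; on this read-out higher numbers stand for weaker inhibition and lower numbers for stronger inhibition:
- compound 1 `Nc1nc2[nH]c(CCSCC(=O)N[C@@H](CCC(=O)O)C(=O)O)cc2c(=O)[nH]1`: 373 nM
- compound 2 `Nc1nc2[nH]c(CCSCC(=O)NCc3cccnc3)cc2c(=O)[nH]1`: 37500 nM
- compound 3 `Nc1nc2[nH]c(CCSCC(=O)NCc3ccccn3)cc2c(=O)[nH]1`: 28400 nM

Compound 3 sits within the scatter of compound 2 and far from compound 1, the step being a 76-fold higher number from compound 1 to compound 3 (1.88 log units; beyond the scatter).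

Compound 4 `Nc1nc2[nH]c(CCSCC(=O)NCc3ccncc3)cc2c(=O)[nH]1` differs from compound 3 in a single group: pyridin-4-yl in place of pyridin-2-yl on a saturated chain carbon bound to an amide-type nitrogen. In words, it carries pyridin-4-yl in place of pyridin-2-yl on a saturated chain carbon bound to an amide-type nitrogen.

Two of the measured steps are large, a 100-fold higher number from compound 1 to compound 2 (2.00 log units; beyond the scatter) and a 76-fold higher number from compound 1 to compound 3 (1.88 log units; beyond the scatter), but both replace 1,3-dicarboxypropyl, a group that neither compound 3 nor compound 4 carries. They say little about this change. For the measured compounds named here, the one measured step that exchanges one pyridinyl group for another is a 1.3-fold lower number from compound 2 to compound 3 (0.12 log units; within the scatter), and it stays within the scatter. Going by the values given here, no pyridin-4-yl compound has been measured, so this single step is the only guide. On that basis, no step beyond the scatter is expected in this assay, and the estimated step is a 1.1-fold higher number from compound 3 to compound 4 (0.02 log units; within the scatter). The value expected for compound 4 is 30000 nM, with an estimated range of 13000 nM to 70000 nM.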

Compound 4, half-maximal inhibitory concentration: 14100 nM
Compound 4: the middle estimate sits 2.1-fold (0.33 log units) above what was measured; the measured number falls inside the stated range.
By their numbers in this assay, from the lowest: compound 1; then compounds 4, 3 and 2 (each within the scatter of the next, the first and the last beyond it).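

For the compounds shown here, with compound 4, all three pyridinyl groups on a saturated chain carbon bound to an amide-type nitrogen can be compared in this assay: the change from pyridin-2-yl to pyridin-4-yl stays within the scatter (a 2.0-fold lower number from compound 3 to compound 4 (0.30 log units; within the scatter)), whereas the change from pyridin-3-yl to pyridin-4-yl is the first exchange of one pyridinyl group for another to go beyond it (a 2.7-fold lower number from compound 2 to compound 4 (0.42 log units; beyond the scatter)), though only modestly. The exchange among these groups is therefore not entirely silent, but it remains small beside the large gap that also separates the (pyridin-4-yl)methyl compound from the 1,3-dicarboxypropyl compound (a 38-fold higher number from compound 1 to compound 4 (1.58 log units; beyond the scatter)), so none of the three pyridinyl groups closes that gap. Nothing available accounts for these differences among the pyridinyl groups.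

The compounds shown leave open whether a longer chain between the amide-type nitrogen and the pyridine ring would change the number in this assay. They also leave open whether an amine or a carboxylic acid on the pyridine ring would bring the number closer to that of compound 1, or whether a single carboxylic acid on the side chain would be enough.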